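Furan-2-yl in place of ethynyl: an expected step

The compounds below may be only part of what the source reports. "The series", "measured", "known", "first", "only" and "open" are said of these compounds alone.

Measured compounds:
compound 1 `Nc1nc(N)c2c(-c3cc4ccccc4o3)cn([C@@H]3O[C@H](CO)[C@@H](O)[C@H]3O)c2n1`: 14000 nM
compound 2 `C#Cc1cn([C@@H]2O[C@H](CO)[C@@H](O)[C@H]2O)c2ncnc(OC)c12`: 5140 nM
compound 3 `CNc1ncnc2c1c(-c1ccsc1)cn2[C@@H]1O[C@H](CO)[C@@H](O)[C@H]1O`: > 20000 nM

In a functional assay on HCT-116 cells (Homo sapiens), read by MTT assay, with a stated time of 72 h (on this read-out higher numbers stand for weaker inhibition and lower numbers for stronger inhibition), compound 2 `C#Cc1cn([C@@H]2O[C@H](CO)[C@@H](O)[C@H]2O)c2ncnc(OC)c12` gives 5140 nM, the lower of the two numbers reported, and compound 1 `Nc1nc(N)c2c(-c3cc4ccccc4o3)cn([C@@H]3O[C@H](CO)[C@@H](O)[C@H]3O)c2n1` gives 14000 nM, a gap that lies beyond the usual scatter. Compound 3 `CNc1ncnc2c1c(-c1ccsc1)cn2[C@@H]1O[C@H](CO)[C@@H](O)[C@H]1O` reaches only a limit of the assay, > 20000 nM, which is not a number; this sits on (the limit of > 20000 nM in this assay, at which 1 of the 3 values shown sits).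

Compound 4 `COc1ncnc2c1c(-c1ccco1)cn2[C@@H]1O[C@H](CO)[C@@H](O)[C@H]1O` has not yet been tested. It differs from compound 2 in one place: furan-2-yl in place of ethynyl on an aromatic carbon. Both compound 1 and compound 3 carry a five-membered aromatic ring at this aromatic carbon, and neither reaches the number of compound 2, so the account expects the step from ethynyl to furan-2-yl to move toward weaker inhibition, by an amount around the edge of the scatter rather than far past it. The expected step of a 1.6-fold higher number from compound 2 to compound 4 (0.19 log units; within the scatter) is estimated on that basis. For compound 4 the estimate is 8000 nM, with a range from 2500 nM to 25000 nM.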

Compound 4, half-maximal inhibitory concentration: 40 nM
Compound 4: the middle estimate sits 200-fold (2.30 log units) above what was measured; measured number outside the range, below it.
By their numbers in this assay, from the lowest: compound 4; then compound 2; then compound 1. At a limit, above all of these: compound 3.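

In this assay, furan-2-yl in place of ethynyl on this aromatic carbon gives a 130-fold lower number from compound 2 to compound 4 (2.11 log units; beyond the scatter) and so shows that a change at this one position can by itself shift the number far beyond the scatter. Compound 1 and compound 3 also carry a five-membered aromatic ring at this carbon, but each differs from compound 4 in more than one place, so neither could give a reading of this change. Nothing measured here accounts for the size of the step.

The compounds shown leave open whether the step depends on the oxygen of the furan or on the ring as a whole, which a phenyl group at this carbon on the same core would help to separate. Also open, on these data alone, is whether the step would persist with an amine in place of the methoxy group of compound 4.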